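Swapping the aryl group on a shared kinase core

The compounds below may be only part of what the source reports. "The series", "measured", "known", "first", "only" and "open" are said of these compounds alone.

Measured so far:
Compound 1, `CCCS(=O)(=O)Nc1ccc(F)c(C(=O)c2n[nH]c3ncc(-c4cccc(O)c4)cc23)c1F`: 2.2% in an assay for binding affinity to dual specificity mitogen-activated protein kinase kinase 4 (Homo sapiens), read by KINOMEscan, tested at 100 nM; a higher number here means a weaker effect of the compound at the concentration tested, a lower number a stronger effect
Compound 2, `CCCS(=O)(=O)Nc1ccc(F)c(C(=O)c2n[nH]c3ncc(-c4ccc(N)cc4)cc23)c1F`: 0.1% in this assay

Of the two numbers shown, the one for compound 2 is the smaller, but its nearest neighbour is compound 1 and the step of a number 2.1 percentage points lower from compound 1 to compound 2 (within the scatter) lies within the scatter, so the two compounds cannot be told apart on this evidence.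

Compound 3, `CCCS(=O)(=O)Nc1ccc(F)c(C(=O)c2n[nH]c3ncc(-c4cc(Cl)cc(Cl)c4)cc23)c1F`, is not yet measured. It differs from compound 2 in one place: 3,5-dichlorophenyl in place of 4-aminophenyl on an aromatic carbon. Within the data shown here, the only measured step that bears on it is the exchange of one aryl group for another at the same place, from compound 1 to compound 2, which gave a number 2.1 percentage points lower from compound 1 to compound 2 (within the scatter) and stayed within the scatter. With both measured compounds near the bottom of the scale, compound 3 is expected to give a step of a number 2.9 percentage points higher from compound 2 to compound 3 (within the scatter), which is not beyond the scatter. The estimate for compound 3 in this assay is therefore 3%, with a range from 0% to 15%.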

Compound 3, a percentage reported as activity, at one concentration (the size of the read-out at that concentration, not a potency): 73%
For compound 3 the middle estimate is 70 percentage points below the measured one, outside the stated range (above it).
By their numbers in this assay, from the lowest: compounds 2 and 1 (each within the scatter of the next); then compound 3.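

The aromatic carbon para to a fused ring is not indifferent to which aryl group it carries. In this assay the exchange of one substituted phenyl for another can stay within the scatter (a number 2.1 percentage points lower from compound 1 to compound 2 (within the scatter)), yet 3,5-dichlorophenyl gives a large loss of effect against both earlier groups: a number 72.9 percentage points higher from compound 2 to compound 3 (beyond the scatter) and a number 70.8 percentage points higher from compound 1 to compound 3 (beyond the scatter). Compound 3 therefore has the weakest effect of the three at the concentration tested, and the near-complete effect of compound 1 and compound 2 proves to belong to those aryl groups rather than to the shared core alone; no measurement on hand explains the difference.

The change from 4-aminophenyl swaps a group with one hydrogen-bond donor and one acceptor for one with neither, while also bringing in two chlorines and moving the substituents, and these three compounds cannot separate those differences. Unsubstituted phenyl, a phenyl with a single chlorine, or one with methyl groups in place of the two chlorines would show whether the loss follows the chlorines, their number or the absence of the amine or hydroxyl.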